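A few compounds are considered here, and "the series" means these few. Any claim that something is new, unique, unknown or untested is made for them only; others in the source may bear on it.

In an ADME assay on BJ cells (Homo sapiens) for cytotoxicity, read by CellTiter-Glo and resazurin assay, with a stated time of 72 h (on this read-out higher numbers stand for an effect only at larger amounts of compound and lower numbers for an effect already at smaller amounts), compound 3 `CCOC(=O)CCCCCOc1cccc(CN(C(=O)c2ccc(-c3ccc4c(c3)OCCO4)cc2)C(C)C)c1` gives only a limit of the assay, > 24400 nM. The two other values known in this assay are limits as well. Compound 1 `CCOC(=O)CCCCCOc1cccc(CN(C(=O)c2ccc(-c3cccc(OCc4ccccc4)c3)cc2)C(C)C)c1` gives > 26000 nM, a limit. Compound 2 `CCOC(=O)CCCCCOc1cccc(CN(C(=O)c2ccc(-c3cccc(OCC)c3)cc2)C(C)C)c1` gives > 22300 nM, likewise a limit. Since all three stand at limits, as the lines (the limit of > 22300 nM in this assay, at which 1 of the 3 values shown sits), the limit of > 24400 nM in this assay, at which 1 of the 3 values shown sits, and the limit of > 26000 nM in this assay, at which 1 of the 3 values shown sits, record, neither a step that the two limits leave unreadable from compound 1 to compound 2 nor a step that the two limits leave unreadable from compound 2 to compound 3 can be read in size or direction. Compound 4 `CCOC(=O)CCCCCOc1cccc(CN(C(=O)c2ccc(-c3cccc(Cl)c3)cc2)C(C)C)c1` differs from compound 3 in one place: 3-chlorophenyl in place of 2,3-dihydro-1,4-benzodioxin-6-yl on an aromatic carbon. The measured steps give no readable size that bears on this change; they show only that none of the three compounds reached an effect within the tested range. The expectation for compound 4 therefore rests on that shared picture, with a step that the limit leaves unreadable from compound 3 to compound 4 expected, most likely reported again as a limit. Compound 4 is expected to give about 25000 nM in this assay, within a range from 10000 nM to 60000 nM.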

Compound 4, half-maximal effective concentration: > 18400 nM
Compound 4 was reported as a limit; the forecaster's own chance of this, stated with the estimate: 80%; the middle value does not contradict the limit.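

In this assay compound 4 gives > 18400 nM, a limit of the assay, and its steps from compound 1, compound 2 and compound 3 cannot be read. The compounds shown leave open where any of them would reach a half-maximal effect, and whether exchanging these groups changes it.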